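Swapping a Prenyl Chain for a Thiophene Carbonyl

A few compounds are considered here, and "the series" means these few. Any claim that something is new, unique, unknown or untested is made for them only; others in the source may bear on it.

Of the compounds shown here, three have been measured in a functional assay (trachea) with Cavia porcellus as the target; on this read-out lower numbers stand for stronger inhibition and higher numbers for weaker inhibition. Compound 1 `Oc1nnc(-c2cccnc2)c2ccccc12` gives 10200 nM in this assay. Compound 2 `CC(C)=CCn1nc(-c2cccnc2)c2ccccc2c1=O` gives 1380 nM, and compound 3 `COC(=O)c1ccc(Cn2nc(-c3cccnc3)c3ccccc3c2=O)cc1` gives 5890 nM. Compound 2 thus shows the lowest number of the three, and its gaps to compound 3 and to compound 1 both lie beyond the usual scatter of repeated measurements, so compound 2 is the strongest inhibitor among them.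

Compound 4 `O=C(c1cccs1)n1nc(-c2cccnc2)c2ccccc2c1=O` has not yet been measured. It differs from compound 2 at a single point: (thiophen-2-yl)carbonyl in place of 3-methylbut-2-en-1-yl on an aromatic nitrogen. The chain that leaves carries no ring; the group that enters brings a five-membered aromatic ring and a carbonyl.

Within the data shown here, no measured pair differs in exactly this way, so the size of the step can only be judged from the three numbers at hand. Compound 3, which carries a different group on that nitrogen, shows a higher number than compound 2, and compound 1 a higher one still. The step of a 2.9-fold higher number from compound 2 to compound 4 (0.46 log units; beyond the scatter) is therefore expected to be a moderate move toward weaker inhibition, beyond the scatter. Compound 4 is expected to give about 4000 nM, within a range from 1200 nM to 13000 nM.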

Compound 4, half-maximal inhibitory concentration: 12300 nM
Compound 4: the middle estimate sits 3.1-fold (0.49 log units) below what was measured; the measured number falls inside the stated range.
By their numbers in this assay, from the lowest: compound 2; then compounds 3, 1 and 4 (each within the scatter of the next, the first and the last beyond it).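

Placing (thiophen-2-yl)carbonyl instead of 3-methylbut-2-en-1-yl on the aromatic nitrogen gives an 8.9-fold higher number from compound 2 to compound 4 (0.95 log units; beyond the scatter) in this assay, so the group on this nitrogen clearly matters, and this exchange weakens inhibition. The entering group differs from the departing chain in more than one way, bringing both a five-membered aromatic ring and a carbonyl, and this single step cannot show which feature goes with the weaker inhibition. No supporting measurement is available to explain the change.

A thiophen-2-ylmethyl group on the same nitrogen would keep the ring without the carbonyl, while a 3-methylbutanoyl group would keep a chain and add the carbonyl, so these two could help separate the contributions of ring and carbonyl. As far as these compounds go, how a longer alkyl chain or a chain ending in an amine, such as 2-aminoethyl, would read at this position also remains open.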